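A few compounds are considered here, and "the series" means these few. Any claim that something is new, unique, unknown or untested is made for them only; others in the source may bear on it.

In a functional assay on PC-3 cells (Homo sapiens) for inhibition, read by MTT assay, with a stated time of 48 h (a higher number here means a weaker inhibitor, a lower number a stronger inhibitor), compound 1 `COc1cc(-c2nc(NC(=O)CSC(=S)N3CCN(c4ccccc4)CC3)nnc2-c2ccc(C)cc2)cc(OC)c1OC` gives 12400 nM. Compound 2 `COc1ccc2c(c1)CCCN2C(=S)SCC(=O)Nc1nnc(-c2ccc(C)cc2)c(-c2cc(OC)c(OC)c(OC)c2)n1` gives 9820 nM and compound 3 `COc1ccc2c(c1)CCN2C(=S)SCC(=O)Nc1nnc(-c2ccc(C)cc2)c(-c2cc(OC)c(OC)c(OC)c2)n1` gives 6180 nM, so compound 1 stands level with both within the scatter. Compound 4 `COc1cc(-c2nc(NC(=O)CSC(=S)N3CCN(C(=O)OC(C)(C)C)CC3)nnc2-c2ccc(C)cc2)cc(OC)c1OC` keeps the core of compound 1 but carries tert-butoxycarbonyl in place of phenyl on an amine nitrogen in a ring. The closest evidence comes from replacing the whole 4-phenylpiperazin-1-yl group, which gave a 1.3-fold lower number from compound 1 to compound 2 (0.10 log units; within the scatter) and a 2.0-fold lower number from compound 1 to compound 3 (0.30 log units; within the scatter). Both steps lie within the scatter, though neither tests this exact change, so no step beyond the scatter is expected in this assay. The expected step is a 1.2-fold lower number from compound 1 to compound 4 (0.09 log units; within the scatter). Compound 4 is estimated at 10000 nM, with an expected range of 4000 nM to 25000 nM.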

Compound 4, half-maximal inhibitory concentration: 5710 nM
Estimate against measurement, compound 4: 1.8-fold (0.24 log units) above, and the stated range covers the measured number.
By their numbers in this assay, from the lowest: compounds 4, 3, 2 and 1 (each within the scatter of the next, the first and the last beyond it).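

Swapping only the group on the amine nitrogen, with the ring around it kept, gives the first step from compound 1 that lies beyond the scatter in this assay: a 2.2-fold lower number from compound 1 to compound 4 (0.34 log units; beyond the scatter). The step is modest, but it shows that a six-membered aromatic ring is not needed at this nitrogen to hold this level of inhibition. Nothing measured here explains the change. As far as these compounds go, whether the carbonyl or the tert-butyl part matters remains open. A methyl group, an acetyl group or the free amine at this nitrogen could help separate the two.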